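Closing a Ring on the Amine: Compound 2 to Compound 3

A few compounds are considered here, and "the series" means these few. Any claim that something is new, unique, unknown or untested is made for them only; others in the source may bear on it.

Measured so far:
compound 1, `CC(CNC1CC1)Oc1cccc2ccc(N)nc12`, gives 50 nM
compound 2, `CC(CNC1CCCC1)Oc1cccc2ccc(N)nc12`, gives 30 nM

Both were tested in an assay on cells with melanin-concentrating hormone receptor 1 (Homo sapiens) as the target, read by radioligand binding; a higher number here means a weaker inhibitor, a lower number a stronger inhibitor. Among the measured compounds shown here, compound 2 has the lower of the two numbers, yet the only measured step, a 1.7-fold lower number from compound 1 to compound 2 (0.22 log units; within the scatter), is too small to count as a real change.

Compound 3, `CC(CN1CCCC1)Oc1cccc2ccc(N)nc12`, has not been measured. It differs from compound 2 in one place: pyrrolidin-1-yl in place of cyclopentylamino on a saturated chain carbon, two bonds along the chain from an oxygen on an aromatic ring. The amine is no longer a separate group hanging off the chain; it becomes part of the ring itself. For the measured compounds named here, no measured step in this set touches this kind of change: the one available step only swapped ring size on the amine and stayed within the scatter. There is therefore no basis for expecting a large shift in either direction, and the estimate for compound 3 is 40 nM, within 10 nM to 160 nM, a step of a 1.3-fold higher number from compound 2 to compound 3 (0.12 log units; within the scatter).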

Compound 3, half-maximal inhibitory concentration: 70 nM
Estimate against measurement, compound 3: 1.8-fold (0.24 log units) below; measured number inside the range.
By their numbers in this assay, from the lowest: compounds 2, 1 and 3 (each within the scatter of the next, the first and the last beyond it).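

In this assay, among the compounds shown here, the step of a 2.3-fold higher number from compound 2 to compound 3 (0.37 log units; beyond the scatter) is the first in this set to clear the scatter, so the form of the amine at this place can register, if only modestly. It comes with the change from cyclopentylamino to pyrrolidin-1-yl, where the hydrogen-bond donors go from 1 to 0. The same swap starting from cyclopropylamino gives a 1.4-fold higher number from compound 1 to compound 3 (0.15 log units; within the scatter) and so does not separate those two compounds, and no data here explain the difference between the two swaps.

The compounds shown leave open whether the shift follows the loss of the amine hydrogen or the ring itself, which methyl(cyclopentyl)amino at this place could help separate. They also leave open how a larger ring such as piperidin-1-yl, or an open-chain dimethylamino group, would read here.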